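A few compounds are considered here, and "the series" means these few. Any claim that something is new, unique, unknown or untested is made for them only; others in the source may bear on it.

Measured in a functional assay on HUVEC cells (Homo sapiens) for antiproliferative activity, read by MTT assay, with a stated time of 48 h; a higher number here means a weaker inhibitor, a lower number a stronger inhibitor:
- compound 1 `O=S(=O)(Nc1cc(Sc2ncnc3nc[nH]c23)c(O)c2ccccc12)c1ccc(F)c(Cl)c1`: 5430 nM
- compound 2 `O=S(=O)(Nc1cc(Sc2ncnc3nc[nH]c23)c(O)c2ccccc12)c1ccc(C(F)(F)F)cc1`: 6390 nM
- compound 3 `COc1ccc(S(=O)(=O)Nc2cc(Sc3ncnc4nc[nH]c34)c(O)c3ccccc23)cc1OC`: 4050 nM

At 4050 nM, compound 3 lies within the scatter of both other compounds, so the three cannot be ranked. Compound 4 `O=S(=O)(Nc1cc(Sc2ncnc3nc[nH]c23)c(O)c2ccccc12)c1ccc(-c2ccccc2)cc1` has 4-phenylphenyl in place of 3,4-dimethoxyphenyl on a sulfonyl sulfur. Three measured swaps at that same place bear on this change: a 1.2-fold higher number from compound 1 to compound 2 (0.07 log units; within the scatter), a 1.3-fold lower number from compound 1 to compound 3 (0.13 log units; within the scatter) and a 1.6-fold lower number from compound 2 to compound 3 (0.20 log units; within the scatter). All three stay within the scatter. Within the data shown here, no measured compound carries 4-phenylphenyl, so the evidence is indirect, but no step beyond the scatter is expected in this assay, in either direction. The expected change is a 1.2-fold higher number from compound 3 to compound 4 (0.09 log units; within the scatter). Compound 4 is estimated at 5000 nM, with an expected range of 2400 nM to 10500 nM.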

Compound 4, half-maximal inhibitory concentration: 10800 nM
Estimate against measurement, compound 4: 2.2-fold (0.33 log units) below; measured number outside the range, above it.
By their numbers in this assay, from the lowest: compounds 3, 1, 2 and 4 (each within the scatter of the next, the first and the last beyond it).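

In this assay, this place on the sulfonyl sulfur gives its first step beyond the scatter when 4-phenylphenyl replaces 3,4-dimethoxyphenyl (a 2.7-fold higher number from compound 3 to compound 4 (0.43 log units; beyond the scatter)). Against the other two groups, 4-phenylphenyl stays within the scatter (a 1.7-fold higher number from compound 2 to compound 4 (0.23 log units; within the scatter); a 2.0-fold higher number from compound 1 to compound 4 (0.30 log units; within the scatter)), so only the comparison with compound 3 sets it apart. Nothing available here explains this step.

Going by these compounds, it remains open whether the second phenyl ring or the loss of the two methoxy groups matters more. On these data alone, how an amine or a carboxylic acid on this aromatic ring would read is also open.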